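Shortening the Amide Chain to an Aminobenzimidazole

This account rests on a few compounds, and the source may have more. Where it says the series, first, only, none or still open, it means among the compounds named here.

Compound 2 `Cc1cc(C)cc(S(=O)(=O)c2c(C(=O)NCC(=O)NCc3ccco3)[nH]c3ccc(Cl)cc23)c1` reaches only the limit of > 50000 nM in an ADME assay on MT4 cells (Homo sapiens) for cytotoxicity, read by MTT assay (a lower number here means that less compound is tolerated, a higher number that more compound is tolerated), so its position is known as a bound alone, the one described by the limit of > 50000 nM in this assay, at which 1 of the 3 values shown sits. Compound 1 `Cc1cc(C)cc(S(=O)(=O)c2c(C(=O)NC(C)C(=O)NCc3ccccc3F)[nH]c3ccc(Cl)cc23)c1` gives 23300 nM in this assay, and compound 3 `Cc1cc(C)cc(S(=O)(=O)c2c(C(=O)NCC(=O)NC(C)c3ccccc3)[nH]c3ccc(Cl)cc23)c1` gives 29400 nM. Going by the values given here, the single measured step that touches compound 2, an at least 1.7-fold lower number from compound 2 to compound 3 (0.23 log units; that floor lies within the scatter), is small. Compound 4 `Cc1cc(C)cc(S(=O)(=O)c2c(C(=O)NCc3ccc4nc(N)[nH]c4c3)[nH]c3ccc(Cl)cc23)c1` differs from compound 2 by 2-amino-1H-benzimidazol-6-yl in place of ((furan-2-yl)methyl)carbamoyl on a saturated chain carbon bound to an amide-type nitrogen. Among the compounds with values here, no measured step covers a change of this kind; the step to compound 3 shows only that exchanging the terminal group moves the number modestly at most. Compound 4 is therefore expected to sit near the bound again, with an at least 1.2-fold lower number from compound 2 to compound 4 (0.09 log units; that floor lies within the scatter) expected to lie within the scatter. Compound 4 is estimated at 40000 nM, between 15000 nM and 100000 nM.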

Compound 4, half-maximal cytotoxic concentration: 5890 nM
For compound 4 the middle estimate is 6.8-fold (0.83 log units) above the measured one; measured number outside the range, below it.
By their numbers in this assay, from the lowest: compound 4; then compounds 1 and 3 (each within the scatter of the next). At a limit, above all of these: compound 2.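

The number for compound 2 is a limit and not a measured value: the limit of > 50000 nM in this assay, at which 1 of the 4 values shown sits. In this assay, 2-amino-1H-benzimidazol-6-yl on this saturated chain carbon gives an at least 8.4-fold lower number from compound 2 to compound 4 (0.92 log units; beyond the scatter) and a 5.0-fold lower number from compound 3 to compound 4 (0.70 log units; beyond the scatter). The earlier exchange of terminal groups had a floor within the scatter, so this is the first change at this position shown to lower the number beyond it. The compounds shown leave open whether the lower number follows the benzimidazole with its amine or the shortened chain. A benzimidazole without the amine, or a longer chain carrying the same group, would separate the two.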